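A few compounds are considered here, and "the series" means these few. Any claim that something is new, unique, unknown or untested is made for them only; others in the source may bear on it.

Three compounds share one core and differ only in the group on a saturated chain carbon bound to an aromatic nitrogen. In an assay on isolated protein for inhibition of aldehyde dehydrogenase 1A1 (Homo sapiens), read by spectrophotometry, tested at 10 uM (on this read-out higher numbers stand for more inhibition at the one concentration tested (going by the name of the read-out) and lower numbers for less inhibition), compound 1 `CC(C)CCn1c(CN2CCN(C(=O)C3CC3)CC2)nc2ccccc21` gives 70%. Compound 2 `O=C(C1CC1)N1CCN(Cc2nc3ccccc3n2Cc2ccc(F)cc2)CC1` gives 32.7%, and compound 3 `CCCCn1c(CN2CCN(C(=O)C3CC3)CC2)nc2ccccc21` gives 18.2%. Compound 3 therefore stands lowest of the three, with a number 14.5 percentage points lower from compound 2 to compound 3 (beyond the scatter) and a number 51.8 percentage points lower from compound 1 to compound 3 (beyond the scatter).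

Compound 4 `O=C(C1CC1)N1CCN(Cc2nc3ccccc3n2CC2CCCC2)CC1` differs from compound 3 in one place: cyclopentyl in place of propyl on a saturated chain carbon bound to an aromatic nitrogen. Among the measured compounds shown here, the steps that bear on this all sit at the same place. Removing a methyl from the isobutyl of compound 1 gave a number 51.8 percentage points lower from compound 1 to compound 3 (beyond the scatter), a large loss, while a number 37.3 percentage points lower from compound 1 to compound 2 (beyond the scatter) and a number 14.5 percentage points lower from compound 2 to compound 3 (beyond the scatter) show the two other groups falling between. Cyclopentyl adds carbon at the place where the loss was seen, so a rise beyond the scatter is expected, though no cyclic group has been measured here. The expected step is a number 31.8 percentage points higher from compound 3 to compound 4 (beyond the scatter), and compound 4 is estimated at 50%, within 25% to 75%.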

Compound 4, a percentage reported as inhibition, at one concentration (the size of the read-out at that concentration, not a potency): 44.5%
Compound 4: the middle estimate sits 5.5 percentage points above what was measured, within the range that was stated.
By their numbers in this assay, from the lowest: compound 3; then compound 2; then compound 4; then compound 1.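

In this assay, among the compounds shown here, cyclopentyl brings a saturated ring to this place for the first time, and the step of a number 26.3 percentage points higher from compound 3 to compound 4 (beyond the scatter) shows that this ring gives a higher number than the straight chain. The saturated ring also outdoes the aromatic one, with a number 11.8 percentage points higher from compound 2 to compound 4 (beyond the scatter) for the swap from 4-fluorophenyl, so among the two ring groups the cyclopentyl gives the higher number. It still falls short of the branched chain, at a number 25.5 percentage points lower from compound 1 to compound 4 (beyond the scatter) for the swap from isobutyl, so more carbon alone does not set the order here.

Nothing measured here explains this ranking. Still open, as far as these compounds go, is whether a cyclohexyl ring, a longer chain such as hexyl, or a chain ending in an amine at this place would match or pass compound 1.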